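This account rests on a few compounds, and the source may have more. Where it says the series, first, only, none or still open, it means among the compounds named here.

Measured so far in a functional assay on the whole organism (artery, strain albino) with Rattus norvegicus as the target, with a stated time of 240 min, at a dose of 10 mg/kg by the oral route; on this read-out higher numbers stand for more inhibition at the one dose given (going by the name of the read-out) and lower numbers for less inhibition:
- compound 1 `COc1ccc(C2N=C(SCc3ccccc3Cl)NC(C)=C2C(=O)Nc2ccc(F)cc2)cc1OC` gives 30.3%
- compound 2 `CC1=C(C(=O)Nc2ccc(Br)cc2)C(c2ccc(Cl)cc2Cl)N=C(SCc2ccccc2)N1` gives 17.4%
- compound 3 `CC1=C(C(=O)Nc2ccc(Br)cc2)C(c2ccc(Cl)cc2Cl)N=C(SCc2ccccc2Cl)N1` gives 28.7%

Among these three numbers compound 3 stands second highest. Its nearest neighbour is compound 1, which lies a little higher, a gap inside the usual scatter; the furthest is compound 2, which lies lower by an amount beyond the scatter. For the measured compounds named here, the only single-point step measured runs from compound 2 to compound 3: a number 11.3 percentage points higher from compound 2 to compound 3 (beyond the scatter).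

The unmeasured compound 4 `CC1=C(C(=O)Nc2ccc(Br)cc2)C(c2ccc(Cl)cc2Cl)N=C(SCc2cccc(Cl)c2)N1` differs from compound 3 in one place: 3-chlorophenyl in place of 2-chlorophenyl on a saturated chain carbon bound to a sulfur. Going by the values given here, no measured step moves a chlorine from one position of this ring to another, so the step from compound 2 to compound 3 bears on it only loosely, showing that adding a chlorine on this ring gave a modest gain. From the compounds shown here alone, whether the 3-chlorophenyl keeps that gain is unknown; the expected step of a number 3.7 percentage points lower from compound 3 to compound 4 (within the scatter) is therefore small and of uncertain direction. Compound 4 is estimated at 25%, within 12% to 38%.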

Compound 4, a percentage reported as inhibition, in the whole organism at one dose (the size of the read-out at that dose, not a potency): 15.9%
Beside the measured number, compound 4's estimate is 9.1 percentage points above it; low and high end bracket the measured number.
By their numbers in this assay, from the lowest: compounds 4 and 2 (each within the scatter of the next); then compounds 3 and 1 (each within the scatter of the next).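

In this assay, the place of the chlorine on this ring counts, not merely its presence: the change to 3-chlorophenyl gives a number 12.8 percentage points lower from compound 3 to compound 4 (beyond the scatter), although the atoms are the same. Chloro in place of hydrogen now reads two ways, since the 2-chlorophenyl gave a number 11.3 percentage points higher from compound 2 to compound 3 (beyond the scatter) while the 3-chlorophenyl gives a number 1.5 percentage points lower from compound 2 to compound 4 (within the scatter), so among these compounds the gain belongs to the 2-chlorophenyl alone. Nothing at hand explains why the two placements part.

From the compounds shown here alone, whether a methyl or a methoxy group in place of the chlorine of the 2-chlorophenyl would hold the number remains open. So does whether the 3-chlorophenyl would bring the same loss on the core of compound 1, with its dimethoxyphenyl and fluorophenyl groups.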